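Coumarin-linked hydrazide: from 2-bromophenyl to 4-fluorophenyl

A few compounds are considered here, and "the series" means these few. Any claim that something is new, unique, unknown or untested is made for them only; others in the source may bear on it.

Compound 1 `Cc1ccc(OCC(=O)NNC(=O)c2cc3ccccc3oc2=O)c(C(=O)c2ccccc2Br)c1` gives 8000 nM in a functional assay on Ehrlich cells (Mus musculus) for cytotoxicity, read by MTT assay, with a stated time of 48 h (a higher number here means a weaker inhibitor, a lower number a stronger inhibitor), the lower of the two numbers recorded there. Among the compounds with values here, compound 2 `Cc1ccc(OCC(=O)NNC(=O)c2cc3ccccc3oc2=O)c(C(=O)c2ccc(Br)cc2)c1` is the only measured neighbour of compound 1. Within the data shown here, compound 2 gives 87300 nM; the step of an 11-fold higher number from compound 1 to compound 2 (1.04 log units; beyond the scatter) is the single measured step, and it corresponds to 4-bromophenyl in place of 2-bromophenyl on a carbonyl carbon.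

Compound 3 `Cc1ccc(OCC(=O)NNC(=O)c2cc3ccccc3oc2=O)c(C(=O)c2ccc(F)cc2)c1` has not been measured. It differs from compound 1 by 4-fluorophenyl in place of 2-bromophenyl on a carbonyl carbon. Among the measured compounds shown here, this change shares with the measured step the move of the halogen from the 2-position of the phenyl to its 4-position, but it also swaps bromine for fluorine, and no measured pair shows what the halogen identity alone does. For the measured compounds named here, compound 2 is therefore the only guide, and it points toward a weaker inhibitor than compound 1 by a large margin, though the size of that shift for a fluorine may well differ.

On that basis compound 3 is expected to give 40000 nM in this assay, within 10000 nM to 150000 nM, a step of a 5.0-fold higher number from compound 1 to compound 3 (0.70 log units; beyond the scatter).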

Compound 3, half-maximal inhibitory concentration: 39700 nM
The estimate for compound 3 lay 1.0-fold (0.00 log units) above the measured number; low and high end bracket the measured number.
By their numbers in this assay, from the lowest: compound 1; then compound 3; then compound 2.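

In this assay, within the data shown here, the step with a 2.2-fold lower number from compound 2 to compound 3 (0.34 log units; beyond the scatter) isolates the halogen for the first time: with fluoro in place of bromo on an aromatic carbon, the change is modest but still beyond the scatter. The second step, with a 5.0-fold higher number from compound 1 to compound 3 (0.70 log units; beyond the scatter), shows that compound 1 also keeps the lower number against a 4-fluorophenyl group, so the 2-bromophenyl compound is the strongest inhibitor of the three, and the gain seen with it is not confined to the comparison with 4-bromophenyl. Nothing available explains why either step takes the direction or size it does.

Still open, from the compounds shown here alone, is how much of the difference between compound 1 and compound 3 comes from where the halogen sits and how much from which halogen it is, since a 2-fluorophenyl group would be needed to separate the two. Going by these compounds, it is also open whether a halogen is needed at all, which an unsubstituted phenyl group on the same carbonyl carbon would test, and whether a 2-methoxyphenyl or 2-methylphenyl group would keep the low number of compound 1.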